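Pyridin-2-yl for Phenyl: Cytotoxicity Outlook for Compound 4

The compounds below may be only part of what the source reports. "The series", "measured", "known", "first", "only" and "open" are said of these compounds alone.

Measured so far:
compound 1, `CCOC(=O)c1sc(-c2ccccc2)nc1N1CCC(NCc2ccc(F)cc2)CC1`: 6.23%
compound 2, `CCOC(=O)c1sc(-c2ccccc2)nc1N1CCC(NCc2ccc(Cl)c(Cl)c2)CC1`: 18.1%
compound 3, `CCOC(=O)c1sc(-c2ccccc2)nc1N1CCC(NCc2ccc(Cl)cc2Cl)CC1`: 9.43%

These numbers come from an ADME assay on RAW264.7 cells (Mus musculus) for cytotoxicity, read by MTT assay, with a stated time of 72 h, tested at 50 uM; a higher number here means more inhibition at the concentration tested (going by the name of the read-out), a lower number less inhibition. Compound 1 holds the lowest number shown, though compound 3 lies within the scatter of it; a number 11.9 percentage points higher from compound 1 to compound 2 (beyond the scatter) is the only step beyond the scatter, and a number 8.7 percentage points lower from compound 2 to compound 3 (within the scatter) stays within it. Compound 4, `CCOC(=O)c1sc(-c2ccccn2)nc1N1CCC(NCc2ccc(F)cc2)CC1`, differs from compound 1 by pyridin-2-yl in place of phenyl on an aromatic carbon. For the measured compounds named here, none of the measured steps touches this position; all three alter only the group on the saturated chain carbon bound to the amine nitrogen, so they offer no direct guide. Lacking such a guide, compound 4 is expected to stay close to compound 1, with a number 1.8 percentage points higher from compound 1 to compound 4 (within the scatter) not beyond the scatter. Compound 4 is therefore estimated at 8%, within the range 0% to 20%.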

Compound 4, a percentage reported as inhibition, at one concentration (the size of the read-out at that concentration, not a potency): 12.6%
Beside the measured number, compound 4's estimate is 4.6 percentage points below it; the range from low to high includes it.
By their numbers in this assay, from the lowest: compounds 1, 3, 4 and 2 (each within the scatter of the next, the first and the last beyond it).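

In this assay, for the compounds shown here, pyridin-2-yl in place of phenyl on this aromatic carbon gives a number 6.4 percentage points higher from compound 1 to compound 4 (within the scatter) and is the first reading at this position, since the earlier steps changed only the group on the saturated chain carbon. Adding one ring nitrogen and one hydrogen-bond acceptor here therefore shows no clear change in the read-out. No measured evidence bears on this step. Still open, as far as these compounds go, is how a carboxylic acid or an amine on this aromatic carbon would read, and whether pyridin-2-yl gives a similar step alongside the 3,4-dichlorophenyl group of compound 2.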